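The source may hold more compounds than are shown below. What is called first, only, known or untested is meant among the compounds shown, and "the series" means these compounds.

In a functional assay (aorta) with Rattus norvegicus as the target (a higher number here means a weaker inhibitor, a lower number a stronger inhibitor), compound 1 `CC(=O)c1ccc(N/C(=N/[C@@H]2c3cc(C#N)ccc3OC(C)(C)[C@H]2O)NC#N)cc1` gives 21000 nM and compound 3 `COc1ccc(N/C(=N/[C@@H]2c3cc(C#N)ccc3OC(C)(C)[C@H]2O)NC#N)cc1` gives 32500 nM. These two values cannot be told apart, since a 1.5-fold higher number from compound 1 to compound 3 (0.19 log units; within the scatter). Compound 2 `CC1(C)Oc2ccc(C#N)cc2[C@@H](/N=C(\NC#N)Nc2cccc(C(=O)O)c2)[C@@H]1O` reaches only a limit of the assay, > 100000 nM. Compound 3 therefore stands level with compound 1, and both stand clear of compound 2, as an at least 3.0-fold lower number from compound 2 to compound 3 (0.48 log units; beyond the scatter) shows.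

Compound 4 `CC1(C)Oc2ccc(C#N)cc2[C@@H](/N=C(\NC#N)Nc2ccc3c(c2)CCC3)[C@@H]1O` has not yet been measured. It keeps the shared core and changes one group: 2,3-dihydro-1H-inden-5-yl in place of 4-methoxyphenyl on an amine nitrogen. In words, 2,3-dihydro-1H-inden-5-yl takes the place of 4-methoxyphenyl on an amine nitrogen.

Among the compounds with values here, no measured step makes this exact change. The closest guide is the swap of acetyl for methoxy, where a 1.5-fold higher number from compound 1 to compound 3 (0.19 log units; within the scatter), so that change in the group on the amine nitrogen left the number within the scatter. The larger steps, an at least 4.7-fold higher number from compound 1 to compound 2 (0.67 log units; beyond the scatter) and an at least 3.0-fold lower number from compound 2 to compound 3 (0.48 log units; beyond the scatter), both involve the 3-carboxyphenyl group, which plays no part in the change to compound 4.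

No shift beyond the scatter is therefore expected in this assay, and the estimated step is a 1.6-fold lower number from compound 3 to compound 4 (0.21 log units; within the scatter). For compound 4 the expected value is 20000 nM, with an estimated range from 6000 nM to 60000 nM.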

Compound 4, half-maximal inhibitory concentration: 41300 nM
The estimate for compound 4 lay 2.1-fold (0.31 log units) below the measured number; measured number inside the range.
By their numbers in this assay, from the lowest: compounds 1, 3 and 4 (each within the scatter of the next). At a limit, above all of these: compound 2.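

In this assay, the 2,3-dihydro-1H-inden-5-yl group brings a five-membered non-aromatic ring of carbon only and has no hydrogen-bond acceptor, yet it leaves the number level with the 4-methoxyphenyl compound (a 1.3-fold higher number from compound 3 to compound 4 (0.10 log units; within the scatter)) and with the 4-acetylphenyl compound (a 2.0-fold higher number from compound 1 to compound 4 (0.29 log units; within the scatter)). At this amine nitrogen, then, three different aryl groups, one of them with no oxygen at all, give values that cannot be told apart, while the separation from the 3-carboxyphenyl compound remains (an at least 2.4-fold lower number from compound 2 to compound 4 (0.38 log units; beyond the scatter)). That last step is only a lower bound, as the value of compound 2 is a limit of the assay, not a number: the limit of > 100000 nM in this assay, at which 1 of the 4 values shown sits.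

Whether the separation of compound 2 comes from the carboxylic acid itself or from its place on the ring stays open, as the compounds shown do not pull those two apart. Also open, on these data alone, is how a plain phenyl group, an amine or a longer alkyl chain on the ring would read in this assay.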